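Methoxy to methyl on a sigma-1 ligand: expected shift

This account rests on a few compounds, and the source may have more. Where it says the series, first, only, none or still open, it means among the compounds named here.

Measured compounds:
- compound 1 `COC1Cc2c(csc2-c2ccc(C)cc2)C2(CCN(Cc3ccccc3)CC2)O1`: 2 nM
- compound 2 `COc1ccc(-c2scc3c2CC(OC)OC32CCN(Cc3ccccc3)CC2)cc1`: 2.2 nM
- compound 3 `COc1ccc(-c2csc3c2CC(OC)OC32CCN(Cc3ccccc3)CC2)cc1`: 7.1 nM

All three values come from an assay on membranes from brain for displacement of a labelled ligand from Sigma non-opioid intracellular receptor 1 (Cavia porcellus), read by scintillation counting, with a stated time of 120 min; on this read-out lower numbers stand for stronger inhibition and higher numbers for weaker inhibition. Compound 1 and compound 2 sit close together, and the step of a 1.1-fold lower number from compound 2 to compound 1 (0.04 log units; within the scatter) shows that this change, (methyl in place of methoxy on an aromatic carbon), left the result essentially unchanged. Compound 3 has the same atoms as compound 2 joined differently; the difference between the two cores is not broken down here. In this assay compound 3 gives 7.1 nM, the highest number of the three.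

Compound 4 `COC1Cc2c(-c3ccc(C)cc3)csc2C2(CCN(Cc3ccccc3)CC2)O1` has not been measured. It differs from compound 3 by methyl in place of methoxy on an aromatic carbon, the same change that separates compound 2 from compound 1, at the same place. Because the earlier step of a 1.1-fold lower number from compound 2 to compound 1 (0.04 log units; within the scatter) was within the scatter, the step of a 1.2-fold lower number from compound 3 to compound 4 (0.07 log units; within the scatter) is expected to be small as well, with compound 4 staying near compound 3. The estimate for compound 4 in this assay is therefore 6 nM, with a likely range from 2.5 nM to 15 nM.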

Compound 4, inhibition constant: 2.7 nM
Estimate against measurement, compound 4: 2.2-fold (0.35 log units) above; the measured number falls inside the stated range.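

In this assay, putting methyl in place of methoxy gives a 2.6-fold lower number from compound 3 to compound 4 (0.42 log units; beyond the scatter) on one core and a 1.1-fold lower number from compound 2 to compound 1 (0.04 log units; within the scatter) on the other, so only the first of these steps lies beyond the scatter. Even so, the two steps cannot be told apart, as repeated measurements would be expected to differ by about this much: the same change on two cores in this assay, a 1.1-fold lower number (0.04 log units; within the scatter) from compound 2 to compound 1 and a 2.6-fold lower number (0.42 log units; beyond the scatter) from compound 3 to compound 4, 2.4-fold (0.38 log units) apart, within the scatter of two such steps. This shows that the results fit a single modest or negligible effect of the change on both cores, but it does not show that the effect is truly identical, and two pairs of compounds are too few to establish a rule for the series.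

The compounds shown carry only 4-methoxyphenyl and 4-methylphenyl, which leaves open how a hydroxyl group, a chlorine atom or an amine at that place would behave on either core. The change also appears on just two cores, so whether it would carry to any other core is an open question.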